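The compounds below may be only part of what the source reports. "The series", "measured", "known", "first", "only" and "open" are said of these compounds alone.

Measured compounds:
Compound 1, `COC(=O)c1sc2cc(C#Cc3ccc(N(C)C)cc3)cnc2c1N`, in a functional assay on NCI-H460 cells (Homo sapiens) for inhibition, read by sulforhodamine B assay, with a stated time of 48 h; a higher number here means a weaker inhibitor of growth, a lower number a stronger inhibitor of growth: 16600 nM
Compound 2, `COC(=O)c1sc2cc(C#Cc3ccsc3)cnc2c1N`, in this assay: 24800 nM

Compound 2 has the higher of the two numbers, but its gap to compound 1 is within the scatter of this assay, so the two cannot be told apart on these data. Compound 3, `COC(=O)c1sc2cc(C#Cc3ccccc3)cnc2c1N`, has not yet been measured. It differs from compound 2 in one place: phenyl in place of thiophen-3-yl on a triple-bonded carbon. Among the measured compounds shown here, no measured pair shows what such an exchange does in this assay. For the measured compounds named here, with only two compounds, both in the same region, the expected step of a 1.2-fold lower number from compound 2 to compound 3 (0.09 log units; within the scatter) is none beyond the scatter, in either direction. Compound 3 is therefore estimated at 20000 nM in this assay, with a range of 8000 nM to 50000 nM.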

Compound 3, concentration for 50% growth inhibition: > 150000 nM
Compound 3: a limit, no number (the forecaster's own chance of this, stated with the estimate: 10%); middle value at least 7.5-fold (0.87 log units) from the limit.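

In this assay compound 3 gives a limit of the assay rather than a number: the limit of > 150000 nM in this assay, at which 1 of the 3 values shown sits.

The group on the triple-bonded carbon therefore matters in this series, since phenyl in place of thiophen-3-yl gives an at least 6.0-fold higher number from compound 2 to compound 3 (0.78 log units; beyond the scatter). Hydrogen in place of dimethylamino on an aromatic carbon gives an at least 9.0-fold higher number from compound 1 to compound 3 (0.95 log units; beyond the scatter), so the unsubstituted phenyl stands apart from both other groups, each of which gives a measured number.

Going by these compounds, it remains open whether only dimethylamino on that aromatic carbon brings back a measurable number, or whether a methoxy group or a primary amine there would do the same. Also open, on these data alone, are whether another five-membered aromatic ring, such as furan-3-yl, behaves like thiophen-3-yl, and how far compound 3 lies beyond its limit.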